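Ortho substituent series: methylsulfanyl to benzyl

This account rests on a few compounds, and the source may have more. Where it says the series, first, only, none or still open, it means among the compounds named here.

Measured so far in this series:
compound 1, `CN(C)C(=O)c1cccnc1NCCCN1CCN(c2ccccc2C#N)CC1`, gives 2 nM in a functional assay for antagonist activity at Alpha-1A adrenergic receptor (Oryctolagus cuniculus); on this read-out higher numbers stand for weaker binding and lower numbers for tighter binding
compound 2, `CN(C)C(=O)c1cccnc1NCCCN1CCN(c2ccccc2-c2ncco2)CC1`, gives 0.316 nM
compound 3, `CSc1ccccc1N1CCN(CCCNc2ncccc2C(=O)N(C)C)CC1`, gives 0.631 nM

Compound 3 stands second highest of the three numbers. Its neighbour is compound 2: the step of a 2.0-fold higher number from compound 2 to compound 3 (0.30 log units; within the scatter) lies within the scatter, so the two cannot be ordered. Its furthest is compound 1: the step of a 3.2-fold lower number from compound 1 to compound 3 (0.50 log units; beyond the scatter) lies beyond the scatter.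

Compound 4, `CN(C)C(=O)c1cccnc1NCCCN1CCN(c2ccccc2Cc2ccccc2)CC1`, differs from compound 3 in one place: benzyl in place of methylsulfanyl on an aromatic carbon.

For the measured compounds named here, two measured steps bear on this. From cyano to a larger group at the same aromatic carbon, the numbers went down both times: a 6.3-fold lower number from compound 1 to compound 2 (0.80 log units; beyond the scatter) and a 3.2-fold lower number from compound 1 to compound 3 (0.50 log units; beyond the scatter). Between the two larger groups themselves, an aromatic ring and methylsulfanyl, the step of a 2.0-fold higher number from compound 2 to compound 3 (0.30 log units; within the scatter) stayed within the scatter. Benzyl brings a further aromatic ring of carbon only to the same position, so the nearest comparison is compound 2 against compound 3, which gave no step beyond the scatter. Expected for compound 4 in this assay is therefore a step of a 1.3-fold lower number from compound 3 to compound 4 (0.10 log units; within the scatter), at most a slight lowering, not beyond the scatter. The estimate for compound 4 is 0.5 nM, in the range 0.15 nM to 1.6 nM.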

Compound 4, dissociation constant: 6.31 nM
Beside the measured number, compound 4's estimate is 13-fold (1.10 log units) below it, outside the stated range (above it).
By their numbers in this assay, from the lowest: compounds 2 and 3 (each within the scatter of the next); then compound 1; then compound 4.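

Working notes on the aromatic carbon ortho to a large group: in this assay a larger group does not by itself bring a lower number, since benzyl, with its seven heavy atoms, reverses the direction of the two earlier replacements of the nitrile (a 3.2-fold higher number from compound 1 to compound 4 (0.50 log units; beyond the scatter)). Carrying an aromatic ring at this place is not enough either, as the 1,3-oxazol-2-yl and benzyl groups both bring one, yet the series shows a 20-fold higher number from compound 2 to compound 4 (1.30 log units; beyond the scatter) and, against the sulfur-bearing group, a 10-fold higher number from compound 3 to compound 4 (1.00 log units; beyond the scatter) on the same shared core, leaving compound 4 as the weakest of the four compounds on this read-out. No measured evidence on these compounds accounts for the rise, so the change can be recorded here but not explained.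

The compounds shown leave open whether the rise goes with the whole benzyl group or with its ring of carbon only, a question that phenyl and cyclohexylmethyl at the same carbon would help to separate. Also open, as far as these compounds go, is how far methoxy or a longer chain such as n-butyl would follow methylsulfanyl or benzyl at this place.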